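The compounds below may be only part of what the source reports. "The series", "measured", "known", "first", "only" and "open" are said of these compounds alone.

Measured so far: compound 1 `Cc1nc(NC(=O)c2ccccc2)c2nn(-c3ccccc3)cc2n1` with 5.6 nM; compound 2 `O=C(c1ccco1)N(C(=O)c1ccco1)c1nc(-c2ccccc2)nc2cn(-c3ccccc3)nc12` with 75 nM.

In an assay on CHO cells for displacement of a labelled ligand from adenosine receptor A3 (Homo sapiens), read by scintillation counting, with a stated time of 60 min (on this read-out higher numbers stand for weaker inhibition and lower numbers for stronger inhibition), compound 1 gives 5.6 nM, the lower of the two numbers; compound 2 gives 75 nM in this assay, a gap beyond the scatter. Compound 3 `CC(=O)Nc1nc(C)nc2cn(-c3ccccc3)nc12` has not yet been measured. It differs from compound 1 by methyl in place of phenyl on a carbonyl carbon, the benzoyl becoming an acetyl. Going by the values given here, no measured pair shows this change, so the size of the step is open. The expectation is a moderate weakening, a 2.7-fold higher number from compound 1 to compound 3 (0.43 log units; beyond the scatter), somewhat beyond the scatter. Compound 3 is estimated at 15 nM, within 4 nM to 60 nM.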

Compound 3, inhibition constant: 300 nM
Beside the measured number, compound 3's estimate is 20-fold (1.30 log units) below it; the whole stated range lies below it.
By their numbers in this assay, from the lowest: compound 1; then compound 2; then compound 3.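

In this assay, going by these compounds alone, methyl in place of phenyl on a carbonyl carbon gives a 54-fold higher number from compound 1 to compound 3 (1.73 log units; beyond the scatter), the first single-place step. This position is therefore sensitive to the group on the carbonyl carbon, and on the shared core, benzoyl to acetyl is enough to lose most of the strength of compound 1. Nothing available explains the size of this step.

Still open, on these data alone, is where a propyl chain, a cyclohexyl or a benzyl on that carbonyl carbon would fall between the phenyl and methyl results. Such groups could help separate the role of the aromatic ring from that of group size.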